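Swapping the Five-Membered Ring on a Fluorinated Nucleoside Core

The source may hold more compounds than are shown below. What is called first, only, known or untested is meant among the compounds shown, and "the series" means these compounds.

Compound 1 `OC[C@H]1O[C@@H](n2cc(F)c3c(-c4cccs4)ncnc32)[C@H](O)[C@@H]1O`: 4300 nM
Compound 2 `OC[C@H]1O[C@@H](n2cc(F)c3c(-c4nccs4)ncnc32)[C@H](O)[C@@H]1O`: 1000 nM

Among the compounds with values here, in a functional assay on HL-60 cells (Homo sapiens) for cytotoxicity, read by XTT assay, with a stated time of 3 days (a lower number here means a stronger inhibitor, a higher number a weaker inhibitor), compound 2 gives the lowest number of the two measured so far, with compound 1 the only neighbour. Within the data shown here, the one measured step, a 4.3-fold lower number from compound 1 to compound 2 (0.63 log units; beyond the scatter), shows that exchanging the five-membered ring on the shared core can move the number beyond the scatter. Compound 3 `OC[C@H]1O[C@@H](n2cc(F)c3c(-c4ccc[nH]4)ncnc32)[C@H](O)[C@@H]1O` carries a different exchange: 1H-pyrrol-2-yl in place of 1,3-thiazol-2-yl on an aromatic carbon. Among the measured compounds shown here, no measured pair shows this particular exchange, so the direction is open. Compound 3 is estimated at 2000 nM, within 500 nM to 8000 nM, a step of a 2.0-fold higher number from compound 2 to compound 3 (0.30 log units; within the scatter) expected to be modest at most.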

Compound 3, half-maximal inhibitory concentration: 3300 nM
Estimate against measurement, compound 3: 1.7-fold (0.22 log units) below; low and high end bracket the measured number.
By their numbers in this assay, from the lowest: compound 2; then compounds 3 and 1 (each within the scatter of the next).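

The lower number of compound 2 does not extend to every nitrogen-containing five-membered ring: with a 3.3-fold higher number from compound 2 to compound 3 (0.52 log units; beyond the scatter), the 1H-pyrrol-2-yl group does not match the 1,3-thiazol-2-yl group. With a 1.3-fold lower number from compound 1 to compound 3 (0.11 log units; within the scatter), compound 3 cannot be told apart from compound 1, so at this position only compound 2 stands apart from the other two. Nothing available explains this difference between the rings.

As far as these compounds go, all three compounds carry a five-membered aromatic ring at this position, so the effect of an amine or a longer carbon chain there remains open.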